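The compounds below may be only part of what the source reports. "The series", "measured", "known", "first", "only" and "open" are said of these compounds alone.

Measured compounds:
compound 1, `CC(=O)Nc1cccc(Nc2cc(NC3CC3)n3ncc(C#N)c3n2)c1`, with 20 mL.min-1.g-1;
compound 2, `CCN(CC)CCN(C)c1ccc(Nc2cc(NC3CC3)n3ncc(C#N)c3n2)cc1NC(C)=O`, with 44 mL.min-1.g-1;
compound 3, `CCN(CCN)c1ccc(Nc2cc(NC3CC3)n3ncc(C#N)c3n2)cc1NC(C)=O`, with 5 mL.min-1.g-1.

In an ADME assay on liver for metabolic stability, with Liver microsome (Homo sapiens) as the target, using microsomes (a higher number here means faster removal of the compound, a lower number slower removal), compound 1 stands second highest of the three numbers. Its nearest neighbour is compound 2, with a 2.2-fold higher number from compound 1 to compound 2 (0.34 log units; beyond the scatter); its furthest is compound 3, with a 4.0-fold lower number from compound 1 to compound 3 (0.60 log units; beyond the scatter). Between the two substituted compounds the gap is an 8.8-fold lower number from compound 2 to compound 3 (0.94 log units; beyond the scatter).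

Compound 4, `CC(=O)Nc1cc(Nc2cc(NC3CC3)n3ncc(C#N)c3n2)ccc1N1CC[C@H](N(C)C)C1`, carries the change (3-(dimethylamino)pyrrolidin-1-yl in place of hydrogen on an aromatic carbon). Both measured steps from compound 1 bear on this change, since each also places a group on that same aromatic carbon of compound 1, yet they point in opposite directions: a 2.2-fold higher number from compound 1 to compound 2 (0.34 log units; beyond the scatter) and a 4.0-fold lower number from compound 1 to compound 3 (0.60 log units; beyond the scatter). With no measured case of a ring-bearing group at that position, the direction for compound 4 cannot be read from the data with confidence, and a step of modest size either way remains possible. Compound 4 is therefore expected to give 22 mL.min-1.g-1 in this assay, with a range from 7 mL.min-1.g-1 to 65 mL.min-1.g-1. That estimate corresponds to an expected step of a 1.1-fold higher number from compound 1 to compound 4 (0.04 log units; within the scatter), which is within the scatter.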

Compound 4, intrinsic clearance in microsomes: 9 mL.min-1.g-1
Compound 4: middle estimate off by 2.4-fold (0.39 log units), on the high side; the range from low to high includes it.
By their numbers in this assay, from the lowest: compounds 3 and 4 (each within the scatter of the next); then compound 1; then compound 2.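

At this aromatic carbon, a ring-bearing group has now been tested: in this assay, 3-(dimethylamino)pyrrolidin-1-yl gives a 2.2-fold lower number from compound 1 to compound 4 (0.35 log units; beyond the scatter), the same direction as the group in compound 3 and against that in compound 2. The two lower compounds cannot be told apart, with a 1.8-fold higher number from compound 3 to compound 4 (0.26 log units; within the scatter), while the ring-bearing group still stands well apart from the (2-(diethylamino)ethyl)(methyl)amino chain, with a 4.9-fold lower number from compound 2 to compound 4 (0.69 log units; beyond the scatter). So among these three groups, only the chain in compound 2 goes above compound 1, and no supporting data explain this difference.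

The compounds shown leave open whether the ring or its dimethylamino group matters more. A morpholine or a piperazine at this carbon, or a pyrrolidine without the amine, would address that question.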